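A few compounds are considered here, and "the series" means these few. Any claim that something is new, unique, unknown or untested is made for them only; others in the source may bear on it.

Measured compounds in a functional assay on CRL2813 cells (Homo sapiens) for cytotoxicity, read by sulforhodamine B assay, with a stated time of 5 days; on this read-out higher numbers stand for weaker inhibition and lower numbers for stronger inhibition:
Compound 1 `O=C(Nc1ccc(I)cc1)N[C@H]1CC[C@H](Oc2ccc(F)cc2)CC1`: 10200 nM
Compound 2 `CSc1ccccc1NC(=O)N[C@H]1CC[C@H](Oc2ccc(F)cc2)CC1`: > 20000 nM (a limit of the assay, not a number)
Compound 3 `COC(=O)c1cccc(NC(=O)N[C@H]2CC[C@H](Oc3ccc(F)cc3)CC2)c1`: 9200 nM

All three share the same core and differ only in the aryl group on the urea nitrogen. In this assay compound 1 and compound 3 sit within the scatter of each other, so neither can be ranked against the other. For compound 2 the assay reports only a limit (the limit of > 20000 nM in this assay, at which 1 of the 3 values shown sits), and the step of an at least 1.9-fold higher number from compound 1 to compound 2 (0.29 log units; that floor lies within the scatter) has a floor that itself lies within the scatter, so it says little about the size of that change.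

Compound 4 `O=C(Nc1cccc(Cl)c1)N[C@H]1CC[C@H](Oc2ccc(F)cc2)CC1` is not yet measured. It differs from compound 1 as follows: 3-chlorophenyl in place of 4-iodophenyl on an amide-type nitrogen. Within the data shown here, no measured step covers this pair directly. Among the measured compounds shown here, the only step that bears on changing the aryl group from compound 1 is the one to compound 2, which gives a floor within the scatter, and the values of compound 1 and compound 3 show that another small change on this ring also stays within the scatter. Compound 4 is therefore expected to show no step beyond the scatter, with a 1.0-fold lower number from compound 1 to compound 4 (0.01 log units; within the scatter). The estimate for compound 4 is 10000 nM, within the range 4000 nM to 25000 nM.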

Compound 4, half-maximal inhibitory concentration: 5900 nM
For compound 4 the middle estimate is 1.7-fold (0.23 log units) above the measured one, within the range that was stated.
By their numbers in this assay, from the lowest: compounds 4, 3 and 1 (each within the scatter of the next). At a limit, above all of these: compound 2.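

In this assay, a further aryl group on the amide-type nitrogen stays level with the earlier ones: a 1.7-fold lower number from compound 1 to compound 4 (0.24 log units; within the scatter), and a 1.6-fold lower number from compound 3 to compound 4 (0.19 log units; within the scatter), so compound 1, compound 3 and compound 4 cannot be ranked against one another. Among these compounds, the new result also gives the first step beyond the scatter at this position: an at least 3.3-fold lower number from compound 2 to compound 4 (0.53 log units; beyond the scatter), which separates 2-(methylsulfanyl)phenyl from 3-chlorophenyl, whereas the floor of the step from 4-iodophenyl to 2-(methylsulfanyl)phenyl stays within the scatter. The size of that new step remains a floor, as compound 2 gives a limit of the assay and not a number: the limit of > 20000 nM in this assay, at which 1 of the 4 values shown sits.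

The compounds shown leave open whether the place of a substituent on the ring or its identity matters more, as 4-iodophenyl and 3-chlorophenyl differ in both, and a 4-chlorophenyl group would separate the two. Also open, going by these compounds, is how an aryl group carrying an amine or a carboxylic acid would read on this nitrogen, and whether any aryl group here can move the number beyond the scatter of compound 1 and compound 3.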